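Swapping a Ring Amine for an Anilino Group

The compounds below may be only part of what the source reports. "The series", "measured", "known", "first", "only" and "open" are said of these compounds alone.

Two compounds have been measured so far:
Compound 1, `Cc1cc(Oc2ccccc2Cl)c(S(C)(=O)=O)cc1C(=O)N=C(N)N`, gives 14 nM in a functional assay for inhibition of sodium/hydrogen exchanger (Oryctolagus cuniculus); a lower number here means a stronger inhibitor, a higher number a weaker inhibitor.
Compound 2, `Cc1cc(N2CCCC2)c(S(C)(=O)=O)cc1C(=O)N=C(N)N`, gives 11 nM in this assay.

Among the measured compounds shown here, compound 2 has the lower of the two numbers, but the only measured step, a 1.3-fold lower number from compound 1 to compound 2 (0.10 log units; within the scatter), lies within the scatter, so neither compound can be called the stronger inhibitor on this evidence.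

Compound 3, `Cc1cc(Nc2cccc(Cl)c2)c(S(C)(=O)=O)cc1C(=O)N=C(N)N`, has not yet been measured. It differs from compound 2 in one place: (3-chlorophenyl)amino in place of pyrrolidin-1-yl on an aromatic carbon. For the measured compounds named here, the one measured step bears directly on this position, since it exchanged a 2-chlorophenoxy group for pyrrolidin-1-yl at the same aromatic carbon and produced no change beyond the scatter. Compound 3 restores a chlorine-bearing phenyl ring at that carbon, now joined through an amino link, so this position seems to tolerate both a small saturated ring and a substituted aromatic ring. The expected step in this assay is a 1.4-fold higher number from compound 2 to compound 3 (0.13 log units; within the scatter), which is no more than the scatter. Compound 3 is therefore estimated at 15 nM, with a likely range from 5 nM to 45 nM.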

Compound 3, half-maximal inhibitory concentration: 33 nM
Estimate against measurement, compound 3: 2.2-fold (0.34 log units) below; measured number inside the range.
By their numbers in this assay, from the lowest: compounds 2 and 1 (each within the scatter of the next); then compound 3.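

The first measured step suggested that this aromatic carbon, ortho to a methylsulfonyl group, might accept quite different groups with little effect, but that no longer holds for every group. In this assay, putting (3-chlorophenyl)amino in place of pyrrolidin-1-yl gives a 3.0-fold higher number from compound 2 to compound 3 (0.48 log units; beyond the scatter), and putting it in place of 2-chlorophenoxy gives a 2.4-fold higher number from compound 1 to compound 3 (0.37 log units; beyond the scatter). Both steps are modest, yet they show that the group at this carbon can shift the number, and that carrying a chlorine-substituted phenyl ring does not by itself keep compound 3 level with compound 1; the data shown offer no measured explanation for this shift.

Compound 3 differs from compound 1 in two features of the same group, the amino link in place of the oxygen link and the 3-chloro in place of the 2-chloro arrangement, so the compounds shown leave open which of the two goes with the higher number. A (2-chlorophenyl)amino group at this carbon would separate those two features, while a piperidin-1-yl group would show whether a second saturated ring stays level with pyrrolidin-1-yl.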